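Changing the Chain on Compound 3: Expected Cell Toxicity

The compounds below may be only part of what the source reports. "The series", "measured", "known", "first", "only" and "open" are said of these compounds alone.

Of the compounds shown here, three sharing one core have been tested in an ADME assay on Huh-7 cells (Homo sapiens) for cytotoxicity, with a stated time of 72 h; on this read-out higher numbers stand for lower toxicity in this test and lower numbers for higher toxicity in this test. Compound 1, `C/C(=C\c1nn(CCC(C)C)c(=O)c(C2=NS(=O)(=O)c3cc(NS(C)(=O)=O)ccc3N2)c1O)C(F)(F)F`, gives only a limit of the assay, > 33000 nM. Compound 2, `CC(C)(C)CCn1nc(-c2cccs2)c(O)c(C2=NS(=O)(=O)c3cc(NS(C)(=O)=O)ccc3N2)c1=O`, likewise gives only a limit, > 1000 nM. Compound 3, `CCC(C)CCn1nc(-c2cccs2)c(O)c(C2=NS(=O)(=O)c3cc(NS(C)(=O)=O)ccc3N2)c1=O`, stands at a limit as well, > 1000 nM. Because two of the three values sit at the limit of > 1000 nM in this assay, at which 2 of the 3 values shown sit, and the third at the limit of > 33000 nM in this assay, at which 1 of the 3 values shown sits, compound 3 cannot be ranked against its neighbours; it simply shares its limit with compound 2. For the measured compounds named here, the one measured step, a step that the two limits leave unreadable from compound 2 to compound 3, is therefore unreadable, since both of its ends are limits and its size cannot be known.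

The new compound 4, `COCCn1nc(-c2cccs2)c(O)c(C2=NS(=O)(=O)c3cc(NS(C)(=O)=O)ccc3N2)c1=O`, differs from compound 3 in one place: methoxy in place of sec-butyl on a saturated chain carbon, two bonds along the chain from an aromatic nitrogen. Going by the values given here, no measured step involves a methoxy group at this place, and the only step on this chain carbon gives no size. The data thus point in neither direction, and the expectation for compound 4 is a step that the limit leaves unreadable from compound 3 to compound 4 of no readable size beyond the scatter. Compound 4 is estimated at 20000 nM, most likely to be reported again only as a limit, within a range from 3000 nM to 100000 nM.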

Compound 4, half-maximal cytotoxic concentration: > 1000 nM
Compound 4: a limit, no number (the forecaster's own chance of this, stated with the estimate: 80%); the middle value lies beyond the limit too.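

In this assay, for the compounds shown here, compound 2, compound 3 and compound 4 all stand at the same limit, and no step among them can be read: the limit of > 1000 nM in this assay, at which 3 of the 4 values shown sit.

Whether methoxy, sec-butyl and tert-butyl on this chain differ at all in cytotoxicity, and at what concentration each of these compounds becomes toxic to the cells, stays open.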